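Cytotoxicity notes on a small acetylated sugar-derived amide series

The source may hold more compounds than are shown below. What is called first, only, known or untested is meant among the compounds shown, and "the series" means these compounds.

Measured compounds:
- compound 1 `C#CCNC(=O)CO[C@H]1O[C@H](COC(C)=O)C=C(OC(C)=O)C1=O`: 282 ug/mL
- compound 2 `CC(=O)OC[C@@H]1C=C(OC(C)=O)C(=O)[C@@H](OCC(=O)NCc2ccccc2)O1`: 163 ug/mL
- compound 3 `C#CCNC(=O)CO[C@H]1O[C@H](COC(C)=O)C=C(OC(C)=O)/C1=C\C(=O)OCC`: 257 ug/mL

In an ADME assay on HII4E cells (Mus musculus) for cytotoxicity, read by MTT assay, with a stated time of 48 h (on this read-out lower numbers stand for stronger inhibition and higher numbers for weaker inhibition), compound 1 gives 282 ug/mL and compound 2 gives 163 ug/mL. The pair differs in one place, (phenyl in place of ethynyl on a saturated chain carbon bound to an amide-type nitrogen), and the step of a 1.7-fold lower number from compound 1 to compound 2 (0.24 log units; within the scatter) is small. The core of compound 3 differs from that of compound 1 in a way not broken down here. In this assay compound 3 gives 257 ug/mL; its values against compound 1 and compound 2 all lie within the scatter, so no order among the three is claimed.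

Compound 4 `CCOC(=O)/C=C1\C(OC(C)=O)=C[C@@H](COC(C)=O)O[C@@H]1OCC(=O)NCc1ccccc1` is not yet measured. It stands to compound 3 as compound 2 stands to compound 1: the change is phenyl in place of ethynyl on a saturated chain carbon bound to an amide-type nitrogen, the same change as in the measured pair. Within the data shown here, on the core of compound 3 the step is expected to be of the same kind and size, a 1.6-fold lower number from compound 3 to compound 4 (0.21 log units; within the scatter), resting on the single measured example a 1.7-fold lower number from compound 1 to compound 2 (0.24 log units; within the scatter). With that step applied to compound 3, the number for compound 4 in this assay is estimated at 160 ug/mL, with a range from 90 ug/mL to 300 ug/mL.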

Compound 4, half-maximal inhibitory concentration: 128 ug/mL
Beside the measured number, compound 4's estimate is 1.3-fold (0.10 log units) above it; the measured number falls inside the stated range.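

In this assay, propargyl to benzyl on the core of compound 3 gives a 2.0-fold lower number from compound 3 to compound 4 (0.30 log units; within the scatter). Set beside the earlier step, the same change reads alike on the two cores: the same change on two cores in this assay, a 1.7-fold lower number (0.24 log units; within the scatter) from compound 1 to compound 2 and a 2.0-fold lower number (0.30 log units; within the scatter) from compound 3 to compound 4, 1.2-fold (0.06 log units) apart, within the scatter of two such steps. This shows that the two steps agree on these two cores, but each lies within the scatter, so it does not show that the change truly shifts the number on either core, nor that the agreement would hold on a further core.

The compounds shown leave open whether any replacement for propargyl and benzyl on the amide-type nitrogen, such as a longer alkyl chain, or a chain ending in an amine or a carboxylic acid, would give a step beyond the scatter in this assay. Also open, as far as these compounds go, is what replacing the acetyl esters with free hydroxyl groups would do on either core.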